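The compounds below may be only part of what the source reports. "The series", "measured", "known", "first", "only" and "open" are said of these compounds alone.

Two amides built on a shared core have been measured in a functional assay on NCI-H226 cells (Homo sapiens) for inhibition, read by colorimetric assay and sulforhodamine B assay, with a stated time of 48 h; on this read-out higher numbers stand for weaker inhibition of growth and lower numbers for stronger inhibition of growth. Compound 1 `CCCCCCCCCCCC[C@@H](O)[C@H]1CC[C@H]([C@H](O)CCCCCCCCCCNC(=O)c2cccs2)O1`, with thiophen-2-yl on the carbonyl carbon, gives 2090 nM. Compound 2 `CCCCCCCCCCCC[C@@H](O)[C@H]1CC[C@H]([C@H](O)CCCCCCCCCCNC(=O)c2ccco2)O1`, with furan-2-yl there, gives 97700 nM, the higher of the two numbers and so the weaker inhibition of growth. Compound 3 `CCCCCCCCCCCC[C@@H](O)[C@H]1CC[C@H]([C@H](O)CCCCCCCCCCNC(=O)c2ccoc2)O1` differs from compound 2 in one place: furan-3-yl in place of furan-2-yl on a carbonyl carbon. Furan-3-yl takes the place of furan-2-yl on the carbonyl carbon, with the same atoms joined differently. Within the data shown here, only one measured step bears on this change, a 47-fold higher number from compound 1 to compound 2 (1.67 log units; beyond the scatter), and it is large. That step exchanged one ring for another at this same place, so it shows sensitivity there but does not measure the new change directly. A smaller move towards a lower number is expected, estimated as a 3.3-fold lower number from compound 2 to compound 3 (0.51 log units; beyond the scatter). For compound 3 the estimated value is 30000 nM, with an expected range of 6000 nM to 120000 nM.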

Compound 3, concentration for 50% growth inhibition: 100000 nM
For compound 3 the middle estimate is 3.3-fold (0.52 log units) below the measured one, within the range that was stated.
By their numbers in this assay, from the lowest: compound 1; then compounds 2 and 3 (each within the scatter of the next).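

Moving the ring's point of attachment, with furan-3-yl in place of furan-2-yl on the carbonyl carbon, changes nothing that can be read in this assay: the step is a 1.0-fold higher number from compound 2 to compound 3 (0.01 log units; within the scatter). The other new step, a 48-fold higher number from compound 1 to compound 3 (1.68 log units; beyond the scatter), is about as large as the one first seen for furan-2-yl, so across these three compounds the large gap goes with replacing thiophen-2-yl by either furan, not with how the furan is joined. Nothing measured here explains that gap.

Still open, going by these compounds, is whether thiophen-3-yl would match thiophen-2-yl, which would show whether the point of attachment matters for the sulfur ring. Also open, on these data alone, is how a phenyl ring at this same place would compare with compound 1 and the two furans.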